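This account rests on a few compounds, and the source may have more. Where it says the series, first, only, none or still open, it means among the compounds named here.

Working notes on the series. Among the measured compounds shown here, compound 1 `COc1ncnc2c1c(I)cn2[C@@H]1O[C@H](CO)[C@@H](O)[C@H]1O` is the only member with an actual number in an ADME assay on BJ cells (Homo sapiens), read by MTT assay, with a stated time of 72 h; a higher number here means a weaker inhibitor, a lower number a stronger inhibitor: there compound 1 gives 91000 nM, already a weak result. Compound 2 `Cc1ncnc2c1c(-c1cccs1)cn2[C@@H]1O[C@H](CO)[C@@H](O)[C@H]1O` returns only a limit of this assay, > 100000 nM. Compound 3 `CN(C)c1ncnc2c1c(-c1cc3ccccc3o1)cn2[C@@H]1O[C@H](CO)[C@@H](O)[C@H]1O` likewise returns only a limit of this assay, > 100000 nM. For the measured compounds named here, two of the three values shown therefore sit at the limit of > 100000 nM in this assay, at which 2 of the 3 values shown sit, and no step between measured compounds is available. Compound 4 `COc1ncnc2c1c(-c1ccco1)cn2[C@@H]1O[C@H](CO)[C@@H](O)[C@H]1O` remains to be measured in this assay; it differs from compound 1 by furan-2-yl in place of iodo on an aromatic carbon. Compound 4 is expected to give 100000 nM, within 40000 nM to 250000 nM. The step of a 1.1-fold higher number from compound 1 to compound 4 (0.04 log units; within the scatter) is expected to stay within the scatter, with a fair chance that only a limit is reported because compound 2 and compound 3 sit at the limit of > 100000 nM in this assay, at which 2 of the 3 values shown sit.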

Compound 4, half-maximal inhibitory concentration: 430 nM
Estimate against measurement, compound 4: 230-fold (2.37 log units) above; the whole stated range lies above it.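

In this assay furan-2-yl in place of iodo on this aromatic carbon gives a 210-fold lower number from compound 1 to compound 4 (2.33 log units; beyond the scatter) with the rest of compound 1 unchanged. Among the compounds shown here, this is the first readable step, and it shows that the group at this one position can by itself move the result by a large margin. No measurement shown accounts for the size of this step. Going by these compounds, whether a phenyl ring, an amine or a carboxylic acid on this carbon would behave like furan-2-yl remains open. Also open, on these data alone, is whether the same exchange has a similar effect on the cores of compound 2 and compound 3.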